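From Carboxylic Acid to Methyl Ester on a Long Chain

A few compounds are considered here, and "the series" means these few. Any claim that something is new, unique, unknown or untested is made for them only; others in the source may bear on it.

Of the compounds shown here, three have so far been tested in a functional assay on the whole organism for antagonist activity, with Mus musculus as the target, at a dose of 10 mg/kg by the subcutaneous route; a higher number here means more inhibition at the dose given (going by the name of the read-out), a lower number less inhibition. Compound 1 `C[C@]1(c2ccc(O)cc2)CSc2cc(O)ccc2[C@H]1CCCCCCCCC[S+]([O-])CCCC(F)(F)C(F)(F)F` gives 101%, compound 2 `C[C@]1(c2ccc(O)cc2)COc2cc(O)ccc2[C@H]1CCCCCCCCC[S+]([O-])CCCC(F)(F)C(F)(F)F` gives 94%, and compound 3 `C[C@]1(c2ccc(O)cc2)CSc2cc(O)ccc2[C@H]1CCCCCCCCC(CCCC(F)(F)C(F)(F)F)C(=O)O` gives 95%. Compound 3 thus lies within the usual scatter of both compound 2 and compound 1, so the three numbers cannot be told apart; all three numbers are level with one another. Compound 4 `COC(=O)C(CCCCCCCC[C@@H]1c2ccc(O)cc2SC[C@]1(C)c1ccc(O)cc1)CCCC(F)(F)C(F)(F)F` is next to be measured in this assay. It differs from compound 3 by one change: methyl in place of hydrogen on an oxygen next to a carbonyl group. Among the compounds with values here, no measured pair shows what this change does. The step of a number 5 percentage points lower from compound 3 to compound 4 (within the scatter) is estimated to be small, no larger than the scatter, and downward if anything. Compound 4 is therefore expected to give 90%, between 70% and 102%.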

Compound 4, a percentage reported as inhibition, in the whole organism at one dose (the size of the read-out at that dose, not a potency): 52%
The estimate for compound 4 lay 38 percentage points above the measured number; the measured number lies below the stated range.
By their numbers in this assay, from the lowest: compound 4; then compounds 2, 3 and 1 (each within the scatter of the next).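

Replacing the carboxy group with methoxycarbonyl gives a number 43 percentage points lower from compound 3 to compound 4 (beyond the scatter) in this assay. The earlier compounds shown here, all level with one another, gave no sign that this position could matter so much, yet here adding one carbon on an oxygen next to a carbonyl group is enough to lose a large part of the inhibition at the dose given. No measurement available here explains this drop.

The compounds shown leave open how a primary amide or an ethyl ester at this position would compare with the carboxylic acid and the methyl ester. They also leave open whether the same change would have a similar effect with a shorter chain.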